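Swapping the trifluoromethoxyphenyl amide for a carbamoylphenyl amide

A few compounds are considered here, and "the series" means these few. Any claim that something is new, unique, unknown or untested is made for them only; others in the source may bear on it.

Measured compounds:
- compound 1, `COC(=O)c1cccc(C(=O)N2CCC(N(C3CC3)S(=O)(=O)c3cccc(C(F)(F)F)c3)CC2)c1`: "not determined" (no result reported)
- compound 2, `CS(=O)(=O)c1ccc(C(=O)N2CCC(N(C3CC3)S(=O)(=O)c3cccc(C(F)(F)F)c3)CC2)cc1`: "not determined" (no result reported)
- compound 3, `O=C(c1cccc(OC(F)(F)F)c1)N1CCC(N(C2CC2)S(=O)(=O)c2cccc(C(F)(F)F)c2)CC1`: 78%

For the measured compounds named here, in an assay on cells for inhibition of Voltage-dependent L-type calcium channel subunit alpha-1C (Homo sapiens), read by FLIPR and calcium flux, tested at 3 uM (on this read-out lower numbers stand for a weaker effect and higher numbers for a stronger effect at the one concentration tested), compound 3 gives 78% and is the only compound of the three with a number; compound 1 carries "not determined" (no result reported) and compound 2 carries "not determined" (no result reported), so no comparison within this set is possible. The untested compound 4, `NC(=O)c1ccccc1C(=O)N1CCC(N(C2CC2)S(=O)(=O)c2cccc(C(F)(F)F)c2)CC1`, differs from compound 3 in one place: 2-carbamoylphenyl in place of 3-(trifluoromethoxy)phenyl on a carbonyl carbon. Going by the values given here, no step between measured compounds is available to calibrate this change. Among the compounds with values here, with only the single value of compound 3 as anchor, and a 2-carbamoylphenyl group replacing a 3-(trifluoromethoxy)phenyl group, the expected outcome is a drop beyond the scatter, estimated as a number 33 percentage points lower from compound 3 to compound 4 (beyond the scatter). Compound 4 is therefore expected to give 45% in this assay, within a range from 15% to 75%.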

Compound 4, a percentage reported as inhibition, at one concentration (the size of the read-out at that concentration, not a potency): 17%
Beside the measured number, compound 4's estimate is 28 percentage points above it, within the range that was stated.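

In this assay, 2-carbamoylphenyl in place of 3-(trifluoromethoxy)phenyl on a carbonyl carbon gives a number 61 percentage points lower from compound 3 to compound 4 (beyond the scatter), the first comparison this set allows. It shows that, with the rest of the molecule unchanged, the read-out at this one concentration depends strongly on the group at this position. Nothing available explains the drop.

The compounds shown do not separate the carbamoyl group from the loss of the trifluoromethoxy group, as both change in this one step. As far as these compounds go, how a carboxylic acid or an amine on that phenyl ring would read also remains open.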